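Series note: open-chain diamine in place of two fused rings

The source may report more compounds than this note shows. Statements on the series, on what has been measured and on what is new or still open speak of the compounds shown alone.

Measured so far:
compound 1 `O=C(O)c1cn(Cc2ccc(-n3cccn3)cc2)c2cc(N3CC4CNCC4C3)c(F)cc2c1=O` — 173000 nM
compound 2 `O=C(O)c1cn(Cc2ccc(-c3ccccc3)cc2)c2cc(N3CC4CNCC4C3)c(F)cc2c1=O` — 33300 nM
compound 3 `COc1c(N2CC[C@@H](CN)C2)c(F)cc2c(=O)c(C(=O)O)cn(Cc3ccc(-c4ccc(F)cc4)cc3)c12` — 60900 nM

All three numbers come from an assay on isolated protein for inhibition of DNA topoisomerase 1 (Homo sapiens), with a stated time of 15 min; on this read-out lower numbers stand for stronger inhibition and higher numbers for weaker inhibition. Compound 2 and compound 3 sit within the usual scatter of each other; only compound 1 lies clearly apart, a 5.2-fold lower number from compound 1 to compound 2 (0.72 log units; beyond the scatter). Compound 4 `CNCCNc1cc2c(cc1F)c(=O)c(C(=O)O)cn2Cc1ccc(-c2ccccc2)cc1` has not yet been run in this assay. It differs from compound 2 in one place: a group of 5 heavy atoms (3 carbon, 2 nitrogen; no ring) in place of a group of 8 heavy atoms (6 carbon, 2 nitrogen; 2 five-membered non-aromatic rings with 1 hetero atom each), on an aromatic carbon. Within the data shown here, no measured step touches this group; the one step in hand, a 5.2-fold lower number from compound 1 to compound 2 (0.72 log units; beyond the scatter), concerns a different group and gives no guide here. With nothing to anchor a direction, the step expected for compound 4 is a 1.7-fold higher number from compound 2 to compound 4 (0.22 log units; within the scatter), with a wide range around it. Compound 4 is estimated at 55000 nM, between 18000 nM and 170000 nM.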

Compound 4, half-maximal inhibitory concentration: > 200000 nM
Compound 4 gave a limit, no number; the forecaster's own chance of this, stated with the estimate: 20%; middle value at least 3.6-fold (0.56 log units) from the limit.
By their numbers in this assay, from the lowest: compounds 2 and 3 (each within the scatter of the next); then compound 1. At a limit, above all of these: compound 4.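

Among these compounds, replacing the group with two five-membered non-aromatic rings by (2-(methylamino)ethyl)amino on this aromatic carbon gives an at least 6.0-fold higher number from compound 2 to compound 4 (0.77 log units; beyond the scatter), the first step in hand at this position. The read-out at this position therefore depends on the group carried there, and this open chain does not hold the level of compound 2. Compound 4 gives a limit, not a number: the limit of > 200000 nM in this assay, at which 1 of the 4 values shown sits.

From the compounds shown here alone, the full size of the step stays open. Also open, going by these compounds, is whether a longer chain, such as (3-(methylamino)propyl)amino, or a primary amine on the ethyl chain would fall the same way.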